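The source may hold more compounds than are shown below. What is called first, only, known or untested is meant among the compounds shown, and "the series" means these compounds.

Compound 1 `Cc1ccc(SCc2ccc(/C=C/C(=O)Nc3ccccc3N)cc2)cc1` is the weakest of the three compounds measured here: in a functional assay on A549 cells (Homo sapiens) for inhibition, read by CCK-8 assay, with a stated time of 72 h, tested at 8 uM (a lower number here means less inhibition of growth, a higher number more inhibition of growth at the concentration tested), compound 1 gives 48.3%. Compound 2 `Cc1cc(C)cc(SCc2ccc(C(=O)Nc3ccccc3N)cc2)c1` and compound 3 `CCc1ccc(SCc2ccc(C(=O)Nc3ccccc3N)cc2)cc1` share a shorter core without the double bond of compound 1, and both inhibit growth more strongly, with compound 2 giving 78.5% and compound 3 giving 91.4% in this assay. Between those two the change reads a number 12.9 percentage points higher from compound 2 to compound 3 (beyond the scatter).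

Compound 4 `CCc1ccc(SCc2ccc(/C=C/C(=O)Nc3ccccc3N)cc2)cc1` keeps the longer core of compound 1 and differs from it in one place: methyl in place of hydrogen on a saturated chain carbon bound to an aromatic carbon. Read one bond further out, this is a (4-methylphenyl)sulfanyl group becoming a (4-ethylphenyl)sulfanyl group. Among the compounds with values here, no measured pair shows exactly this exchange. Within the data shown here, the only step that touches the entering group is the one from compound 2 to compound 3, where a 4-ethylphenyl replaced a different ring and brought a modest rise, so a modest rise is expected here too, though the core differs. Compound 4 is therefore estimated at 58%, between 40% and 76%, meaning an expected step of a number 9.7 percentage points higher from compound 1 to compound 4 (within the scatter).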

Compound 4, percent growth inhibition at one concentration: 68.6%
The estimate for compound 4 lay 10.6 percentage points below the measured number; the range from low to high includes it.
By their numbers in this assay, from the lowest: compound 1; then compounds 4 and 2 (each within the scatter of the next); then compound 3.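

The exchange of (4-methylphenyl)sulfanyl for (4-ethylphenyl)sulfanyl, which adds a single carbon, changes the result in this assay, with a number 20.3 percentage points higher from compound 1 to compound 4 (beyond the scatter). The earlier step at this position replaced one substituted ring with another on the shorter core, whereas this pair isolates a methyl-to-ethyl change on the longer core. Growth inhibition at this concentration therefore responds to a one-carbon change at this position, but nothing available here explains why.

From the compounds shown here alone, whether the number keeps rising with a longer chain such as propyl or butyl, or what a branched isopropyl, an amine or a carboxylic acid would do at this place, stays open. Also open, going by these compounds, is whether methyl to ethyl would give a similar step on the shorter core of compound 3.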